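A few compounds are considered here, and "the series" means these few. Any claim that something is new, unique, unknown or untested is made for them only; others in the source may bear on it.

Measured in a functional assay on HL-60 cells (Homo sapiens) for antiproliferative activity, read by sulforhodamine B assay, with a stated time of 72 h; on this read-out higher numbers stand for weaker inhibition and lower numbers for stronger inhibition:
- compound 1 `CN(C)C(=S)N/N=C/c1ccc2ccccc2n1`: 50 nM
- compound 2 `COc1ccc(C)cc1NC(=S)N/N=C/c1ccc2ccccc2n1`: > 100000 nM (a limit of the assay)
- compound 3 `CN(C)C(=S)N/N=C/c1cnc2ccccc2n1`: 90 nM

Compound 3 stands within the scatter of compound 1, so these two numbers give no order. Compound 2 gives > 100000 nM, and this is a limit rather than a number.

Compound 4 `NC(=S)N/N=C/c1cnc2ccccc2n1` keeps the core of compound 3 and changes one group: amino in place of dimethylamino on a thiocarbonyl carbon. This puts amino in place of dimethylamino on a thiocarbonyl carbon. Going by the values given here, no measured pair isolates this change, so the expectation is tentative. Both compounds with numerical values carry dimethylamino. Among the compounds with values here, the only compound without it is compound 2, at > 100000 nM, which is the sole guide to replacing that group. In this assay, a step beyond the scatter towards a higher number, meaning weaker inhibition, is therefore expected, though not one reaching the limit. The estimated step is a 17-fold higher number from compound 3 to compound 4 (1.22 log units; beyond the scatter). For compound 4 the expected value is 1500 nM. The expected range for compound 4 runs from 200 nM to 15000 nM.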

Compound 4, half-maximal inhibitory concentration: > 100000 nM
Compound 4: no number, only a limit; the forecaster's own chance of this, stated with the estimate: 10%; middle value at least 66-fold (1.82 log units) from the limit.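

Going by these compounds alone, the pair gives the first direct reading of this position in this assay: amino in place of dimethylamino on a thiocarbonyl carbon gives an at least 1100-fold higher number from compound 3 to compound 4 (3.04 log units; beyond the scatter). Compound 4 gives > 100000 nM, which is a limit of the assay and not a number. Among the compounds shown, only compound 1 and compound 3 give numerical values, and both carry dimethylamino, while the two without it end at the same limit: the limit of > 100000 nM in this assay, at which 2 of the 4 values shown sit.

The compounds shown leave open whether methylamino, or a ring amine such as pyrrolidine or piperidine, on the same carbon would give a numerical value or also end at the limit. Also open, going by these compounds, are how far compound 4 lies past its limit and whether amino has the same outcome on the core of compound 1.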